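Aryl Substituents at the Benzylamine of Phenylpropanoic Acids

A few compounds are considered here, and "the series" means these few. Any claim that something is new, unique, unknown or untested is made for them only; others in the source may bear on it.

Compound 1 `O=C(O)CCc1ccc(NCc2ccccc2)cc1`: 89%
Compound 2 `O=C(O)CCc1ccc(NCc2cccc(C(F)(F)F)c2)cc1`: 102%
Compound 3 `O=C(O)CCc1ccc(OCc2ccc(Oc3ccccc3)cc2)cc1`: 98%

Of the compounds shown here, three have been measured in a functional assay on 1321-N1 cells for agonist activity at Free fatty acid receptor 1 (Homo sapiens), read by calcium flux; on this read-out higher numbers stand for larger maximal responses and lower numbers for smaller maximal responses. Compound 1 gives 89% in this assay, compound 2 gives 102%, and compound 3 gives 98%. The number for compound 2 is the largest of the three, though compound 3 lies within the scatter of it; only compound 1 sits beyond the scatter, a number 13 percentage points higher from compound 1 to compound 2 (beyond the scatter).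

Compound 4 `Cc1ccc(-c2cccc(CNc3ccc(CCC(=O)O)cc3)c2)cc1` has not yet been measured. It differs from compound 2 by 4-methylphenyl in place of trifluoromethyl on an aromatic carbon. For the measured compounds named here, the only measured step that touches this position is the one from compound 1 to compound 2, which was a number 13 percentage points higher from compound 1 to compound 2 (beyond the scatter); it tells how trifluoromethyl compares with hydrogen, not with 4-methylphenyl. Going by the values given here, compound 3 carries a second aromatic ring through a different linker and shows a response close to that of compound 2, but no single-change step connects it to either compound. Since compound 2 already responds near the reference and nothing measured points to a loss, little movement beyond the scatter is expected. Compound 4 is therefore estimated at 98%, with a range from 84% to 110%. For compound 4 the expected step is a number 4 percentage points lower from compound 2 to compound 4 (within the scatter).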

Compound 4, largest response reached (reported as efficacy), in percent of the reference or control that the assay uses: 92%
Beside the measured number, compound 4's estimate is 6 percentage points above it; low and high end bracket the measured number.
By their numbers in this assay, from the lowest: compounds 1, 4, 3 and 2 (each within the scatter of the next, the first and the last beyond it).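

Compound 4 shows that this position, on an aromatic carbon meta to a large group, accepts a second six-membered aromatic ring without a loss of maximal response beyond the scatter in this assay: replacing trifluoromethyl with 4-methylphenyl, a larger group of 7 heavy atoms, gives a number 10 percentage points lower from compound 2 to compound 4 (within the scatter). Set against hydrogen at the same carbon, the new group gives a number 3 percentage points higher from compound 1 to compound 4 (within the scatter), so its response cannot be told apart from that with hydrogen either, even though trifluoromethyl and hydrogen do stand apart, with a number 13 percentage points higher from compound 1 to compound 2 (beyond the scatter). No measurement shown here accounts for these responses, so the reason for them remains unknown.

The compounds shown leave open whether a plain phenyl without the methyl, a methoxy group, a nitrile or a carboxylic acid at this carbon would give a response in the same range, and whether the 4-methylphenyl group would behave alike at another carbon of that ring. They also leave open how these changes affect anything beyond maximal response, since the read-out given here says nothing about the concentration needed to reach it.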